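Toward compound 4: an aminoethyl replacement on a proline-like core

The source may hold more compounds than are shown below. What is called first, only, known or untested is meant among the compounds shown, and "the series" means these compounds.

Compound 3, `N[C@@]1(C(=O)O)CN(Cc2ccncc2)C[C@@H]1CCCB(O)O`, is tested in an assay for inhibition of arginase-1 (Homo sapiens), read by colorimetric assay, with a stated time of 60 min, in the presence of a further agent that is not named here (a higher number here means a weaker inhibitor, a lower number a stronger inhibitor), where compound 3 gives 600 nM. Among the three measured compounds this is the highest number; compound 1, `Cc1[nH]ncc1CN1C[C@H](CCCB(O)O)[C@](N)(C(=O)O)C1`, gives 400 nM, and the pair lies within the scatter, as a 1.5-fold higher number from compound 1 to compound 3 (0.18 log units; within the scatter) shows. Compound 2, `C[C@H](N)CN1C[C@H](CCCB(O)O)[C@](N)(C(=O)O)C1`, gives 7.7 nM, and the large 78-fold higher number from compound 2 to compound 3 (1.89 log units; beyond the scatter) sets it far apart.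

Compound 4, `C[C@@H](N)CN1C[C@H](CCCB(O)O)[C@](N)(C(=O)O)C1`, carries the change (1-aminoethyl in place of pyridin-4-yl on a saturated chain carbon bound to an amine nitrogen in a ring). The measured steps that bear on it are a 52-fold lower number from compound 1 to compound 2 (1.72 log units; beyond the scatter) and a 78-fold higher number from compound 2 to compound 3 (1.89 log units; beyond the scatter), both large, both pointing toward a much lower number once the 1-aminoethyl group is present. Compound 4 shares that group with compound 2 but differs in the defined stereocentre, for which no measured comparison exists here.

The author therefore expects compound 4 to land well below compound 3, estimated at 25 nM with a range from 6 nM to 150 nM, which would mean an expected step of a 24-fold lower number from compound 3 to compound 4 (1.38 log units; beyond the scatter).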

Compound 4, half-maximal inhibitory concentration: 16 nM
The estimate for compound 4 lay 1.6-fold (0.19 log units) above the measured number; the measured number falls inside the stated range.
By their numbers in this assay, from the lowest: compound 2; then compound 4; then compounds 1 and 3 (each within the scatter of the next).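

Among the compounds shown here, compound 4 shows that the large gain from the 1-aminoethyl group at this position does not depend on a single configuration at its stereocentre, as a 38-fold lower number from compound 3 to compound 4 (1.57 log units; beyond the scatter) and a 25-fold lower number from compound 1 to compound 4 (1.40 log units; beyond the scatter) now stand for the R form, just as the earlier steps stood for the S form. The stereocentre at this saturated chain carbon adds a further, much smaller effect, and a 2.1-fold higher number from compound 2 to compound 4 (0.32 log units; beyond the scatter) can be laid to the change from S to R alone, because nothing else separates the pair: the fact that compounds 2 and 4 differ only in the configuration as drawn

From the compounds shown here alone, whether the amine of the 2-aminopropyl group is what carries the gain stays open, and a plain propyl group at this place would speak to that. Going by these compounds, how far the amine may sit from the ring nitrogen also stays open, a question for a longer chain ending in the same amine.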